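Pyrrolidin-1-yl for piperidin-1-yl on a thiocarbonyl carbon

The source may hold more compounds than are shown below. What is called first, only, known or untested is meant among the compounds shown, and "the series" means these compounds.

In a functional assay on DU-145 cells (Homo sapiens) for inhibition, read by MTT assay, with stated times of 18 h and 4 h (a lower number here means a stronger inhibitor, a higher number a weaker inhibitor), compound 1 (`CCCCCCCCCCCCCCCCOP(=O)(O)OCCSC(=S)N1CCN(C)CC1`) gives 49300 nM, and compound 2 (`CCCCCCCCCCCCCCCCOP(=O)(O)OCCSC(=S)N1CCCCC1`) gives 14700 nM. Compound 2 therefore holds the lower of the two numbers and is the stronger inhibitor of this pair. Compound 3 (`CCCCCCCCCCCCCCCCOP(=O)(O)OCCSC(=S)N1CCCC1`) has yet to be measured in this assay. It differs from compound 2 by a single change on the thiocarbonyl carbon: pyrrolidin-1-yl in place of piperidin-1-yl on a thiocarbonyl carbon. For the measured compounds named here, only one measured step bears on this change, and it does so indirectly. That step, a 3.4-fold lower number from compound 1 to compound 2 (0.53 log units; beyond the scatter), put piperidin-1-yl in place of 4-methylpiperazin-1-yl at the same place. It shows that the group on the thiocarbonyl carbon can move the number, but its size is modest. Going by the values given here, no measured compound carries pyrrolidin-1-yl, so the data give no direction for the new step. A change smaller than that measured step is expected, with no shift beyond the scatter. The expected step is a 1.1-fold lower number from compound 2 to compound 3 (0.02 log units; within the scatter). Compound 3 is estimated at 14000 nM, with an expected range of 6500 nM to 30000 nM.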

Compound 3, half-maximal inhibitory concentration: 28900 nM
Beside the measured number, compound 3's estimate is 2.1-fold (0.31 log units) below it, and the stated range covers the measured number.
By their numbers in this assay, from the lowest: compounds 2, 3 and 1 (each within the scatter of the next, the first and the last beyond it).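

In this assay, the new step to pyrrolidin-1-yl (a 2.0-fold higher number from compound 2 to compound 3 (0.29 log units; within the scatter)) lies within the scatter, and so does the step that replaces 4-methylpiperazin-1-yl with the same group (a 1.7-fold lower number from compound 1 to compound 3 (0.23 log units; within the scatter)). Compound 3 therefore cannot be separated from either compound 2 or compound 1, although those two are separated from each other (a 3.4-fold lower number from compound 1 to compound 2 (0.53 log units; beyond the scatter)). The earlier pair suggested that the group on the thiocarbonyl carbon could move the number, but the change from the six-membered to the five-membered ring gives no step that stands clear of the scatter, and nothing available here offers an explanation for this result.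

The compounds shown leave open whether a morpholin-4-yl group, a seven-membered ring amine or an open-chain diethylamino group on the thiocarbonyl carbon would give a step beyond the scatter from compound 2. All three compounds also share the rest of the core, so they do not show how a shorter alkyl chain would act together with any of these ring groups.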